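Swapping an aryl ring for piperidine at the bombesin-3 agonist tail

The source may hold more compounds than are shown below. What is called first, only, known or untested is meant among the compounds shown, and "the series" means these compounds.

Measured compounds:
compound 1, `CCC(C)(C)Cc1c[nH]c(CCc2ccc(-n3ncnn3)cc2)n1`, 89 nM
compound 2, `CCC(C)(C)Cc1c[nH]c(CCc2ccc(-c3ccc(F)cn3)cc2)n1`, 97 nM

In a functional assay on HEK293 cells for agonist activity at Bombesin receptor subtype-3 (Homo sapiens), read by luminescence and calcium flux, with a stated time of 10 min (on this read-out lower numbers stand for an effect already at smaller amounts and higher numbers for an effect only at larger amounts of compound), compound 1 gives 89 nM and compound 2 gives 97 nM. Among the compounds with values here, compound 2 sits alongside compound 1, and the only measured step, a 1.1-fold higher number from compound 1 to compound 2 (0.04 log units; within the scatter), shows that exchanging one aromatic ring for another at the para position left the number essentially unchanged.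

Compound 3, `CCC(C)(C)Cc1c[nH]c(CCc2ccc(N3CCCCC3)cc2)n1`, differs from compound 2 in a single place: piperidin-1-yl in place of 5-fluoropyridin-2-yl on an aromatic carbon. Here a non-aromatic ring replaces an aromatic one, which no measured step covers directly; the one step available, a 1.1-fold higher number from compound 1 to compound 2 (0.04 log units; within the scatter), concerned two aromatic rings and stayed within the scatter. With no data on a saturated ring at this position, the estimate for compound 3 in this assay is 150 nM, within a range of 40 nM to 600 nM, corresponding to an expected step of a 1.5-fold higher number from compound 2 to compound 3 (0.19 log units; within the scatter).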

Compound 3, half-maximal effective concentration: 108 nM
The estimate for compound 3 lay 1.4-fold (0.14 log units) above the measured number, within the range that was stated.
By their numbers in this assay, from the lowest: compounds 1, 2 and 3 (each within the scatter of the next).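

The result shows that this position, on an aromatic carbon para to a large group, also accepts a non-aromatic ring: in this assay, piperidin-1-yl in place of 5-fluoropyridin-2-yl gives a 1.1-fold higher number from compound 2 to compound 3 (0.05 log units; within the scatter), and piperidin-1-yl in place of 2H-tetrazol-2-yl gives a 1.2-fold higher number from compound 1 to compound 3 (0.08 log units; within the scatter). The earlier pair covered aromatic rings only, whereas these three compounds show that an aromatic ring at this place is not needed for a number of this size. Nothing measured here gives a reason for this result.

The compounds leave open whether the position accepts anything other than a ring, such as an open-chain dimethylamino group, a carboxylic acid or a simple methyl group. They also leave open whether morpholine, or a piperidine carrying a hydroxyl group, would stay within the scatter of these three.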